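Swapping the aryl group on the shared core: compound 4

The source may hold more compounds than are shown below. What is called first, only, known or untested is meant among the compounds shown, and "the series" means these compounds.

Measured so far in a functional assay on HepG2 cells (Homo sapiens) for antiproliferative activity, read by MTT assay, with a stated time of 48 h; on this read-out lower numbers stand for stronger inhibition and higher numbers for weaker inhibition:
compound 1 `COc1ccc(C(=O)c2cccc(Cl)c2)cc1OC(=O)CCC(=O)OC[C@@H]1C=C[C@H](n2cc(C)c(=O)[nH]c2=O)O1` gives 11100 nM
compound 2 `COc1ccc(C(=O)c2ccc([N+](=O)[O-])cc2)cc1OC(=O)CCC(=O)OC[C@@H]1C=C[C@H](n2cc(C)c(=O)[nH]c2=O)O1` gives 24000 nM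
compound 3 `COc1cc(OC)c(C(=O)c2ccc(OC)c(OC(=O)CCC(=O)OC[C@@H]3C=C[C@H](n4cc(C)c(=O)[nH]c4=O)O3)c2)cc1OC` gives 6850 nM

Compound 3 has the lowest number of the three, but one of its two gaps is a 1.6-fold lower number from compound 1 to compound 3 (0.21 log units; within the scatter), within the scatter, while the other is a 3.5-fold lower number from compound 2 to compound 3 (0.54 log units; beyond the scatter). Compound 4 `COc1ccc(C(=O)c2ccc(F)cc2)cc1OC(=O)CCC(=O)OC[C@@H]1C=C[C@H](n2cc(C)c(=O)[nH]c2=O)O1` is not yet measured; it differs from compound 3 in one place: 4-fluorophenyl in place of 2,4,5-trimethoxyphenyl on a carbonyl carbon. Among the compounds with values here, two measured steps bear on changing the aryl group at this carbonyl, a 2.2-fold higher number from compound 1 to compound 2 (0.33 log units; beyond the scatter) and a 3.5-fold lower number from compound 2 to compound 3 (0.54 log units; beyond the scatter), and both were modest. A step of a 1.8-fold higher number from compound 3 to compound 4 (0.24 log units; within the scatter) is therefore expected, a small rise towards the number of compound 1, 11100 nM, which also carries a halogen on that ring. Compound 4 is estimated at 12000 nM, with a range of 5000 nM to 30000 nM.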

Compound 4, half-maximal inhibitory concentration: 20300 nM
For compound 4 the middle estimate is 1.7-fold (0.23 log units) below the measured one; the measured number falls inside the stated range.
By their numbers in this assay, from the lowest: compounds 3, 1, 4 and 2 (each within the scatter of the next, the first and the last beyond it).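

In this assay, the 4-fluorophenyl group gives up ground against 2,4,5-trimethoxyphenyl at this carbonyl, with a 3.0-fold higher number from compound 3 to compound 4 (0.47 log units; beyond the scatter). Yet compound 4 cannot be separated from either of the other two aryl variants, with a 1.2-fold lower number from compound 2 to compound 4 (0.07 log units; within the scatter) and a 1.8-fold higher number from compound 1 to compound 4 (0.26 log units; within the scatter), even though those two variants differ modestly from each other. Nothing measured here explains these steps. Open, as far as these compounds go, is whether an aryl ring carrying an amine or a carboxylic acid would match compound 3 or go beyond it.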